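Swapping the aryl amide on a nitrobenzofurazan thioether chain

The source may hold more compounds than are shown below. What is called first, only, known or untested is meant among the compounds shown, and "the series" means these compounds.

Three compounds share one long chain ending in a nitro-bearing core, and differ only in the aromatic group on the amide nitrogen. Compound 1 `O=C(CCC(=O)OCCCCCCSc1ccc([N+](=O)[O-])c2nonc12)Nc1ccccc1F` gives 4270 nM in an ADME assay on L02 cells (Homo sapiens) for cytotoxicity, read by MTT assay, with a stated time of 72 h; on this read-out lower numbers stand for stronger inhibition and higher numbers for weaker inhibition. Compound 2 `COc1ccccc1NC(=O)CCC(=O)OCCCCCCSc1ccc([N+](=O)[O-])c2nonc12` gives 4490 nM in this assay. Compound 3 `O=C(CCC(=O)OCCCCCCSc1ccc([N+](=O)[O-])c2nonc12)Nc1cccc(Cl)c1` gives 6930 nM in this assay. The steps of a 1.1-fold higher number from compound 1 to compound 2 (0.02 log units; within the scatter), a 1.6-fold higher number from compound 1 to compound 3 (0.21 log units; within the scatter) and a 1.5-fold higher number from compound 2 to compound 3 (0.19 log units; within the scatter) all stay within the scatter, so the three numbers cannot be told apart.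

Compound 4 `COc1ccc(NC(=O)CCC(=O)OCCCCCCSc2ccc([N+](=O)[O-])c3nonc23)cc1` has not yet been measured. It differs from compound 3 by 4-methoxyphenyl in place of 3-chlorophenyl on an amide-type nitrogen. The nearest guides are the two earlier swaps of the aromatic group on this nitrogen, from compound 1 to compound 3 and from compound 2 to compound 3, and the exchange of fluoro for methoxy from compound 1 to compound 2; none moved the number beyond the scatter. The step from compound 3 to compound 4 is therefore expected to be a 1.3-fold lower number from compound 3 to compound 4 (0.10 log units; within the scatter), with no change beyond the scatter. Compound 4 is estimated at 5500 nM in this assay, in a range from 2500 nM to 12000 nM.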

Compound 4, half-maximal inhibitory concentration: 8170 nM
Beside the measured number, compound 4's estimate is 1.5-fold (0.17 log units) below it, within the range that was stated.
By their numbers in this assay, from the lowest: compounds 1, 2, 3 and 4 (each within the scatter of the next).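

In this assay, for the compounds shown here, moving from 2-methoxyphenyl to 4-methoxyphenyl on the amide-type nitrogen gives a 1.8-fold higher number from compound 2 to compound 4 (0.26 log units; within the scatter) and offers the first comparison of one substituent at two ring positions. The other new steps, a 1.2-fold higher number from compound 3 to compound 4 (0.07 log units; within the scatter) and a 1.9-fold higher number from compound 1 to compound 4 (0.28 log units; within the scatter), also stay within the scatter. Across compounds 1, 2, 3 and 4, neither changing the substituent nor changing its ring position moves the number beyond the scatter, so this nitrogen has so far accepted all four aryl groups without a readable difference.

Every group shown here is a substituted phenyl, so the effect of a pyridine ring, a carboxylic acid on the ring or a plain alkyl chain in its place remains open. Nothing available explains why these four compounds read alike.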